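The source may report more compounds than this note shows. Statements on the series, on what has been measured and on what is new or still open speak of the compounds shown alone.

Measured compounds:
compound 1 `Cc1ccc(C(=O)Nc2ccc(Cl)cc2C(N)=O)cc1` — 5.39 ug/mL
compound 2 `Cc1ccc(-c2nc(N)c3cc(Cl)ccc3n2)cc1` — 3.76 ug/mL
compound 3 `Cc1ccc(-c2nc(NN)c3cc(Cl)ccc3n2)cc1` — 3.76 ug/mL

In a functional assay on MCF7 cells (Homo sapiens) for antiproliferative activity, read by MTT assay, with a stated time of 48 h (on this read-out lower numbers stand for stronger inhibition and higher numbers for weaker inhibition), compound 3 gives 3.76 ug/mL, level with compound 2 and within the scatter of compound 1; all three numbers sit close together, none set apart from the others.

Compound 4 `Cc1ccc(-c2nc(NOC(=O)c3ccccc3)c3cc(Cl)ccc3n2)cc1` differs from compound 3 by benzoyloxy in place of amino on a nitrogen on an aromatic ring. Going by the values given here, the one measured step on the same aromatic-ring nitrogen, no change at the digits printed from compound 2 to compound 3 (within the scatter), left the number unchanged. Among the compounds with values here, no measured step introduces a benzoyloxy group, so nothing bears directly on this change beyond that null result. A step of no more than the scatter is therefore expected: a 1.1-fold lower number from compound 3 to compound 4 (0.03 log units; within the scatter). Compound 4 is estimated at 3.5 ug/mL, with a range of 1.2 ug/mL to 10 ug/mL.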

Compound 4, half-maximal inhibitory concentration: 5.59 ug/mL
Compound 4: middle estimate off by 1.6-fold (0.20 log units), on the low side, and the stated range covers the measured number.
By their numbers in this assay, from the lowest: compounds 2, 3, 1 and 4 (each within the scatter of the next).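

In this assay the nitrogen on the aromatic ring carries benzoyloxy, a far larger group than amino, with a 1.5-fold higher number from compound 3 to compound 4 (0.17 log units; within the scatter) and with a 1.5-fold higher number from compound 2 to compound 4 (0.17 log units; within the scatter) when benzoyloxy replaces hydrogen. Hydrogen, amino and benzoyloxy at this position therefore all remain within the scatter of one another, so this change, despite the added aromatic ring and carbonyl, does not separate the compounds. No supporting measurement accompanies this result. On these data alone, it remains open whether acetoxy, a longer alkyl chain or a carboxylic acid on this nitrogen would give a step beyond the scatter.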